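Sulfonylpiperazine Replacing Piperidine on the Chain

The compounds below may be only part of what the source reports. "The series", "measured", "known", "first", "only" and "open" are said of these compounds alone.

Compound 2 `COc1cc(N)c(Cl)cc1C(=O)NC1CCN(CCN2CCCCC2)CC1` is one of two measured compounds; in a functional assay on HEK293 cells for agonist activity at 5-hydroxytryptamine receptor 4 (Homo sapiens), read by cAMP accumulation (on this read-out higher numbers stand for an effect only at larger amounts of compound and lower numbers for an effect already at smaller amounts), compound 2 gives 100 nM. The other, compound 1 `CCN1CCC(NC(=O)c2cc(Cl)c(N)cc2OC)CC1`, gives in this assay 79.4 nM, and the two values sit within the scatter of each other: the step from compound 1 to compound 2 is a 1.3-fold higher number from compound 1 to compound 2 (0.10 log units; within the scatter), brought about by piperidin-1-yl in place of hydrogen on a saturated chain carbon, two bonds along the chain from an amine nitrogen in a ring.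

Compound 3 `COc1cc(N)c(Cl)cc1C(=O)NC1CCN(CCN2CCN(S(C)(=O)=O)CC2)CC1` differs from compound 2 by 4-(methylsulfonyl)piperazin-1-yl in place of piperidin-1-yl on a saturated chain carbon, two bonds along the chain from an amine nitrogen in a ring. Within the data shown here, no measured pair shows this exchange; the only step available, a 1.3-fold higher number from compound 1 to compound 2 (0.10 log units; within the scatter), is small, so the chain terminus appears tolerant, and no step beyond the scatter is expected for compound 3 in this assay. The estimate is therefore a 1.3-fold higher number from compound 2 to compound 3 (0.11 log units; within the scatter), giving compound 3 an expected 130 nM with a range of 40 nM to 420 nM.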

Compound 3, half-maximal effective concentration: 20 nM
Compound 3: middle estimate off by 6.5-fold (0.81 log units), on the high side; measured number below the stated range.
By their numbers in this assay, from the lowest: compound 3; then compounds 1 and 2 (each within the scatter of the next).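

In this assay the saturated chain carbon, two bonds along the chain from an amine nitrogen in a ring, proves sensitive to the group it carries: the exchange gives a 5.0-fold lower number from compound 2 to compound 3 (0.70 log units; beyond the scatter) while piperidin-1-yl in place of hydrogen had stayed within the scatter. Set against the hydrogen of compound 1, 4-(methylsulfonyl)piperazin-1-yl gives a 4.0-fold lower number from compound 1 to compound 3 (0.60 log units; beyond the scatter) and so leaves compound 3 with the lowest number of the three, which shows that the outcome depends on which ring is attached, not merely on a ring being present. Nothing available here accounts for the size or direction of this step.

From the compounds shown here alone, what remains open is which part of the new group goes with the lower number, the methylsulfonyl or the second ring nitrogen. A plain piperazine, an acetyl in place of the methylsulfonyl, or a morpholine at this place could separate these, and a longer chain could test whether the spacing matters.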